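Fluoro on the phenyl of a sulfamide-bearing piperidine series

A few compounds are considered here, and "the series" means these few. Any claim that something is new, unique, unknown or untested is made for them only; others in the source may bear on it.

Compound 1 `NS(=O)(=O)NCCC1CCN(c2cc(-c3ccccc3)ncn2)CC1` is the parent of this pair. Within the data shown here, in a functional assay on HT-29 cells (Homo sapiens) for antiproliferative activity, read by sulforhodamine B assay, with a stated time of 48 h (on this read-out lower numbers stand for stronger inhibition of growth and higher numbers for weaker inhibition of growth), compound 1 gives 66500 nM, the highest of the two numbers measured so far. Among the measured compounds shown here, compound 2 `COC(=O)c1ccc(-c2cc(N3CCC(CCNS(N)(=O)=O)CC3)ncn2)cc1` carries a methoxycarbonyl on the phenyl and gives 19600 nM in this assay; the single measured step, a 3.4-fold lower number from compound 1 to compound 2 (0.53 log units; beyond the scatter), is the only comparison in hand.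

Compound 3 `NS(=O)(=O)NCCC1CCN(c2cc(-c3ccccc3F)ncn2)CC1` differs from compound 1 by fluoro in place of hydrogen on an aromatic carbon. For the measured compounds named here, no measured step bears directly on this change: the step from compound 1 to compound 2 concerns a different group at a different place, and nothing shows what a fluoro does here. Going by the values given here, with no comparable precedent, the expected outcome is a step of no more than the scatter in either direction. Compound 3 is therefore estimated at 60000 nM in this assay, with a range from 25000 nM to 150000 nM, meaning an expected step of a 1.1-fold lower number from compound 1 to compound 3 (0.04 log units; within the scatter).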

Compound 3, concentration for 50% growth inhibition: 51800 nM
Estimate against measurement, compound 3: 1.2-fold (0.06 log units) above; measured number inside the range.
By their numbers in this assay, from the lowest: compound 2; then compounds 3 and 1 (each within the scatter of the next).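

In this assay the change from phenyl to 2-fluorophenyl gives a 1.3-fold lower number from compound 1 to compound 3 (0.11 log units; within the scatter) and so a single fluoro ortho to a large group does not separate compound 3 from compound 1. Among these compounds, this is the first reading for a change at this place on the phenyl, whereas the earlier step of a 3.4-fold lower number from compound 1 to compound 2 (0.53 log units; beyond the scatter) concerns methoxycarbonyl at a different place and lies beyond the scatter. No measurement shown here offers an explanation for the size of the fluoro step.

Going by these compounds, whether a larger group at this same place, such as chloro, methoxy or an amine, would move the number beyond the scatter remains open. Also open, on these data alone, is whether fluoro at another place on the phenyl, or fluoro together with methoxycarbonyl, would read any differently.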